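The source may report more compounds than this note shows. Statements on the series, on what has been measured and on what is new or still open speak of the compounds shown alone.

Measured so far in a physicochemical assay for solubility, read by HPLC, in phosphate buffer, measured as kinetic solubility, at pH 7.4; a lower number here means a less soluble compound, a higher number a more soluble compound
compound 1 `CCC(=O)c1cc(-c2ccc(S(N)(=O)=O)cc2)n(-c2ccccc2Cl)n1` gives 4700 nM
compound 2 `CCC(=O)c1cc(-c2ccc(S(N)(=O)=O)cc2)n(-c2ccc(OC)cc2)n1` gives 64300 nM

Of these two, compound 2 holds the higher number, and its gap to compound 1 lies beyond the scatter. Within the data shown here, the next structure is compound 3 `CCC(=O)c1cc(-c2ccc(S(N)(=O)=O)cc2)n(-c2ccc(Cl)cn2)n1`, which has 5-chloropyridin-2-yl in place of 4-methoxyphenyl on an aromatic nitrogen at the same place that changed in the one measured step. That step, a 14-fold higher number from compound 1 to compound 2 (1.14 log units; beyond the scatter) in this assay and large, put 4-methoxyphenyl in place of 2-chlorophenyl. Among the measured compounds shown here, compound 3 gives up the 4-methoxyphenyl of compound 2 and, like compound 1, holds chlorine on that ring, but no measured compound has the 5-chloropyridin-2-yl itself. A fall beyond the scatter is therefore expected, probably smaller than the measured step. The expected change is a 5.4-fold lower number from compound 2 to compound 3 (0.73 log units; beyond the scatter) in this estimate. Compound 3 is estimated at 12000 nM with an expected range of 3500 nM to 40000 nM in this assay.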

Compound 3, solubility: 33700 nM
Beside the measured number, compound 3's estimate is 2.8-fold (0.45 log units) below it; measured number inside the range.
By their numbers in this assay, from the lowest: compound 1; then compounds 3 and 2 (each within the scatter of the next).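

In this assay the change from 2-chlorophenyl to 5-chloropyridin-2-yl on the aromatic nitrogen gives a 7.2-fold higher number from compound 1 to compound 3 (0.86 log units; beyond the scatter), so chlorine on this ring does not go with a low number in every case. Set against 4-methoxyphenyl, the same group gives a 1.9-fold lower number from compound 2 to compound 3 (0.28 log units; within the scatter), although the two groups differ in ring atoms and in substituent, which leaves compound 1 alone apart from the other two. Nothing on hand offers a reason for either step.

Going by these compounds, compound 1 and compound 3 differ both in the ring nitrogen and in where the chlorine sits, so the share of each in that step stays open. Also open, on these data alone, is how this position would read with a ring bearing an amine or a carboxylic acid, or with an unsubstituted phenyl.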